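Swapping a Benzyl Arm for a Prenyl Chain

The compounds below may be only part of what the source reports. "The series", "measured", "known", "first", "only" and "open" are said of these compounds alone.

Measured so far:
- Compound 1, `CN(Cc1ccccc1)CC1CCN(CCCc2c[nH]c3ccc(-n4cnnc4)cc23)CC1`: 0.9 nM
- Compound 2, `CC(=O)Nc1ccc(CNC2CCN(CCCc3c[nH]c4ccc(-n5cnnc5)cc34)CC2)cc1`: 3 nM

Both compounds were tested in an assay on CHO cells for displacement of a labelled ligand from 5-hydroxytryptamine receptor 1D (Homo sapiens); on this read-out lower numbers stand for stronger inhibition and higher numbers for weaker inhibition. Compound 1 gives 0.9 nM, the lowest of the two numbers. Compound 2 gives 3 nM, a higher number, and that gap lies beyond the usual scatter of repeated runs. No stepwise comparison between the two is available, because they differ in more than one place, so only the two values themselves can be read.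

Compound 3, `CC(C)=CCN(C)C1CCN(CCCc2c[nH]c3ccc(-n4cnnc4)cc23)CC1`, has not yet been measured in this assay. Its structure differs from compound 1 in a single place: methyl(3-methylbut-2-en-1-yl)amino in place of (benzyl(methyl)amino)methyl on a saturated ring carbon. The group that leaves carries an aromatic ring, while the group that enters has no ring and a double bond instead, and the nitrogen now sits directly on the saturated ring carbon rather than one carbon further out.

Since both measured compounds give low numbers with rather different groups at this place, a step of modest size toward weaker binding seems the most likely outcome, though a result within the scatter would not be surprising. Compound 3 is therefore estimated at 3 nM, with a plausible range from 1 nM to 10 nM. The expected step from compound 1 to compound 3 is a 3.3-fold higher number from compound 1 to compound 3 (0.52 log units; beyond the scatter).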

Compound 3, half-maximal inhibitory concentration: 0.5 nM
For compound 3 the middle estimate is 6.0-fold (0.78 log units) above the measured one; measured number outside the range, below it.
By their numbers in this assay, from the lowest: compounds 3 and 1 (each within the scatter of the next); then compound 2.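

In this assay, putting methyl(3-methylbut-2-en-1-yl)amino in place of (benzyl(methyl)amino)methyl gives a 1.8-fold lower number from compound 1 to compound 3 (0.26 log units; within the scatter), so this read-out does not separate the two compounds. The change removes the six-membered aromatic ring, brings in a double bond, and places the nitrogen directly on the saturated ring carbon, yet compound 3 still gives a value as low as that of compound 1, so in this pair an aromatic ring in this group is not required for a low number. Nothing measured here explains why the number holds across this change.

Because the ring and the link to the nitrogen changed in the same step, the compounds shown cannot tell their separate contributions apart, and a benzyl(methyl)amino group placed directly on the saturated ring carbon would pull the two apart. As far as these compounds go, it also remains open how much of this group is needed at all, for example whether a plain dimethylamino group, or a chain ending in a carboxylic acid, would keep the number this low.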